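Moving a Methyl Group Around the Phenyl Ring

This account rests on a few compounds, and the source may have more. Where it says the series, first, only, none or still open, it means among the compounds named here.

Compound 1, `CCCc1ccccc1-n1nc(C)c2c1NC(=O)[C@H](C)S[C@@H]2c1ccc(Oc2ccccc2)cc1`, gives 1100 nM in an assay on isolated protein for agonist activity at Bile acid receptor (Homo sapiens), read by AlphaScreen, with a stated time of 30 min; a higher number here means that more compound is needed for the effect, a lower number that less compound is needed. Compound 2, `Cc1ccc(-n2nc(C)c3c2NC(=O)[C@H](C)S[C@@H]3c2ccc(Oc3ccccc3)cc2)cc1`, gives 3400 nM in this assay.

Going by the values given here, compound 2 has the highest number of the two measured, and the only measured step, a 3.1-fold higher number from compound 1 to compound 2 (0.49 log units; beyond the scatter), leads to it. Compound 3, `Cc1cccc(-n2nc(C)c3c2NC(=O)[C@H](C)S[C@@H]3c2ccc(Oc3ccccc3)cc2)c1`, changes one thing: 3-methylphenyl in place of 4-methylphenyl on an aromatic nitrogen. Among the compounds with values here, no measured step moves a methyl group around this ring, so the single step above is the only guide, and it shows that what sits on this ring can matter modestly. For compound 3 the expected step is a 1.4-fold lower number from compound 2 to compound 3 (0.13 log units; within the scatter), a shift within the scatter. Compound 3 is therefore expected to give 2500 nM, between 800 nM and 8000 nM, in this assay.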

Compound 3, half-maximal effective concentration: 2400 nM
The estimate for compound 3 lay 1.0-fold (0.02 log units) above the measured number; the measured number falls inside the stated range.
By their numbers in this assay, from the lowest: compound 1; then compounds 3 and 2 (each within the scatter of the next).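

Shifting the methyl group from 4-methylphenyl to 3-methylphenyl gives a 1.4-fold lower number from compound 2 to compound 3 (0.15 log units; within the scatter) in this assay, so the two methylphenyl compounds cannot be told apart here. The other new comparison, a 2.2-fold higher number from compound 1 to compound 3 (0.34 log units; beyond the scatter), shows that compound 1, with its 2-propylphenyl group, keeps a real edge over compound 3 as well as over compound 2. No available evidence explains these numbers.

Still open, going by these compounds, is whether that edge belongs to the propyl chain or to where it sits on the ring. A 2-methylphenyl or a 3-propylphenyl group would help separate the two.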